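Removing a methyl from the aryl ring of a succinimide amide

The source may report more compounds than this note shows. Statements on the series, on what has been measured and on what is new or still open speak of the compounds shown alone.

The measured compounds:
- compound 1, `CCC(C(=O)N1CCN(c2ccccc2)CC1)N1C(=O)CCC1=O`, 25%
- compound 2, `CC(C(=O)N1CCN(c2cccc(F)c2)CC1)N1C(=O)CCC1=O`, 75%
- compound 3, `Cc1cccc(N2CCN(C(=O)C(C)N3C(=O)CCC3=O)CC2)c1`, 0%

In a functional assay on the whole organism (strain Swiss) with Mus musculus as the target, in the maximal electroshock model, with a stated time of 0.25 h, at a dose of 100 mg/kg by the intraperitoneal route (on this read-out higher numbers stand for a stronger effect at the one dose given and lower numbers for a weaker effect), compound 3 stands lowest of the three; its nearest neighbour is compound 1, and compound 2 lies furthest above it. Compound 4, `CC(C(=O)N1CCN(c2ccccc2)CC1)N1C(=O)CCC1=O`, has not yet been measured. The change from compound 3 to compound 4 is hydrogen in place of methyl on an aromatic carbon, so the 3-methylphenyl of compound 3 becomes a plain phenyl.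

Among the compounds with values here, only one measured step touches this position: a number 75 percentage points lower from compound 2 to compound 3 (beyond the scatter), a large fall when methyl replaced fluoro there. Compound 4 carries neither group. Within the data shown here, compound 1, which also carries a plain phenyl but an ethyl instead of a methyl on the chain, gives 25% in this assay, and no step is recorded between it and compound 4.

Given that the methyl coincides with the large drop a number 75 percentage points lower from compound 2 to compound 3 (beyond the scatter), its removal is expected to restore part of the activity, an upward step of a number 40 percentage points higher from compound 3 to compound 4 (beyond the scatter). Compound 4 is therefore estimated at 40%, within a range of 5% to 80%.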

Compound 4, a percentage reported as activity, at one dose (the size of the read-out at that dose, not a potency): 50%
Beside the measured number, compound 4's estimate is 10 percentage points below it; the measured number falls inside the stated range.
By their numbers in this assay, from the lowest: compound 3; then compound 1; then compound 4; then compound 2.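

In this assay the plain phenyl gives this place on the ring a baseline, and the step of a number 50 percentage points higher from compound 3 to compound 4 (beyond the scatter) ties a large loss to the 3-methylphenyl. Fluoro turns out to be the better of the two groups, since hydrogen in place of fluoro gives a number 25 percentage points lower from compound 2 to compound 4 (beyond the scatter) and so the order among these three compounds is fluoro, then hydrogen, then methyl. The aryl ring is not the only sensitive place, as the step of a number 25 percentage points higher from compound 1 to compound 4 (beyond the scatter) comes from hydrogen in place of methyl on a saturated chain carbon with the phenyl unchanged.

On these data alone, whether a chloro or a methoxy at this place would stand nearer to fluoro or to methyl remains open. No measurement shown here explains why these small changes move the number.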